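Replacing a methyl with difluoromethoxy on the shared core

The compounds below may be only part of what the source reports. "The series", "measured", "known", "first", "only" and "open" are said of these compounds alone.

Measured so far:
compound 1 `Cc1ccc2c(c1)[C@H](C)N(C(=O)c1ccc(Cl)cc1)[C@H](C)CO2` — 150 nM
compound 2 `C[C@@H]1COc2ccc(C#N)cc2[C@H](C)N1C(=O)c1ccc(Cl)cc1` — 8200 nM

In a functional assay on CHO cells for antagonist activity at Orexin receptor type 2 (Homo sapiens), read by FLIPR and calcium flux (on this read-out higher numbers stand for weaker inhibition and lower numbers for stronger inhibition), compound 1 gives the lowest of the two numbers; compound 2 lies a step away of a 55-fold higher number from compound 1 to compound 2 (1.74 log units; beyond the scatter). Compound 3 `C[C@@H]1COc2ccc(OC(F)F)cc2[C@H](C)N1C(=O)c1ccc(Cl)cc1` differs from compound 1 by difluoromethoxy in place of methyl on an aromatic carbon. Going by the values given here, the only step that bears on this change is the one from compound 1 to compound 2, where a cyano replaced the same methyl and the number rose sharply. A similar direction is expected here, though with a smaller move: for compound 3 the estimated step is a 10-fold higher number from compound 1 to compound 3 (1.00 log units; beyond the scatter), giving an expected value of 1500 nM, within a range of 300 nM to 8000 nM.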

Compound 3, half-maximal inhibitory concentration: 27 nM
The estimate for compound 3 lay 56-fold (1.74 log units) above the measured number; measured number outside the range, below it.
By their numbers in this assay, from the lowest: compound 3; then compound 1; then compound 2.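

In this assay, replacing the methyl on this aromatic carbon need not raise the number: difluoromethoxy lowers it (a 5.6-fold lower number from compound 1 to compound 3 (0.74 log units; beyond the scatter)), the opposite direction to the cyano in compound 2. The two replacements also lie far apart (a 300-fold lower number from compound 2 to compound 3 (2.48 log units; beyond the scatter)), so the group at this one place can move the number strongly either way. No measurement here explains this difference.

With only methyl, cyano and difluoromethoxy shown at this carbon, it remains open how a methoxy, a trifluoromethoxy or an amine would read. As far as these compounds go, whether any of them would give a lower number than compound 3 also remains open.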